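Cytotoxicity notes on the ether swap, compound 3 to 4

The source may report more compounds than this note shows. Statements on the series, on what has been measured and on what is new or still open speak of the compounds shown alone.

Compound 1 `N#Cc1ccccc1-c1cc(-c2cc(Cl)cc(OCCC(F)(F)F)c2)c(=O)n(-c2cccnc2)c1` was tested in an ADME assay on 16HBE14o- cells (Homo sapiens) for cytotoxicity, read by MTT assay, with a stated time of 72 h (on this read-out higher numbers stand for lower toxicity in this test and lower numbers for higher toxicity in this test), and gives 25000 nM. For compound 2 `Cc1ocnc1COc1cc(Cl)cc(-c2cc(-c3ccccc3C#N)cn(-c3cccnc3)c2=O)c1` the entry in this assay reads "not determined" (no result reported). Compound 3 `Cc1scnc1COc1cc(Cl)cc(-c2cc(-c3c[nH]c(=O)[nH]c3=O)cn(-c3cccnc3)c2=O)c1` gives 22000 nM in this assay, and this number and that of compound 1 lie within the scatter of each other, so no order can be read between them. Compound 4 `O=c1[nH]cc(-c2cc(-c3cc(Cl)cc(OCc4ocnc4C(F)(F)F)c3)c(=O)n(-c3cccnc3)c2)c(=O)[nH]1` is the next entry; it differs from compound 3 by a group of 9 heavy atoms (4 carbon, 1 nitrogen, 1 oxygen, 3 fluorine; one five-membered aromatic ring with 2 hetero atoms) in place of a group of 6 heavy atoms (4 carbon, 1 nitrogen, 1 sulfur; one five-membered aromatic ring with 2 hetero atoms), on a saturated chain carbon bound to an oxygen on an aromatic ring. Within the data shown here, no step between measured compounds covers such a change, so the step in this assay is expected to be small, with no direction beyond the scatter: no change at the digits printed from compound 3 to compound 4 (within the scatter) is the estimate. For compound 4 a value of 22000 nM is expected in this assay, within a range from 8000 nM to 50000 nM.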

Compound 4, half-maximal cytotoxic concentration: > 100000 nM
Compound 4: no number, only a limit; the forecaster's own chance of this, stated with the estimate: 20%; at least 4.5-fold (0.65 log units) between middle value and limit.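

Among these compounds, at the saturated chain carbon bound to an oxygen on an aromatic ring, the group is not neutral in this assay: the swap gives an at least 4.5-fold higher number from compound 3 to compound 4 (0.65 log units; beyond the scatter), the first step beyond the scatter. Compound 4 reaches a limit of the assay, > 100000 nM, not a number. The step therefore has a floor but no measured size: the limit of > 100000 nM in this assay, at which 1 of the 4 values shown sits.

The compounds shown do not separate the trifluoromethyl group from the exchange of ring sulfur for ring oxygen. On these data alone, how an amine or a carboxylic acid at that place would read in this assay also stays open.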